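Nitro for methyl on the aryl ring of the series

The source may hold more compounds than are shown below. What is called first, only, known or untested is meant among the compounds shown, and "the series" means these compounds.

Compound 2 `Cc1ccc(-c2nnc(CSc3nnc(/N=C/c4ccccc4O)s3)o2)cc1` gives 8750 nM in a functional assay on MCF7 cells (Homo sapiens) for inhibition, read by CCK-8 assay (a higher number here means a weaker inhibitor, a lower number a stronger inhibitor), and compound 1 `Oc1ccccc1/C=N/c1nnc(SCc2nnc(-c3ccccc3Br)o2)s1` gives 9140 nM, the two within the scatter of each other. Compound 3 `O=[N+]([O-])c1ccc(-c2nnc(CSc3nnc(/N=C/c4ccccc4O)s3)o2)cc1` carries nitro in place of methyl on an aromatic carbon. Within the data shown here, the one step touching that ring, a 1.0-fold lower number from compound 1 to compound 2 (0.02 log units; within the scatter), changed nothing beyond the scatter, so a further swap at the same carbon is expected to move the number little in either direction; an expected step of a 1.1-fold lower number from compound 2 to compound 3 (0.04 log units; within the scatter) is set. Compound 3 is therefore estimated at 8000 nM, with a range from 3500 nM to 18000 nM.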

Compound 3, half-maximal inhibitory concentration: 4250 nM
Beside the measured number, compound 3's estimate is 1.9-fold (0.27 log units) above it, and the stated range covers the measured number.
By their numbers in this assay, from the lowest: compound 3; then compounds 2 and 1 (each within the scatter of the next).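

In this assay, the substituent on this aryl ring can move the number beyond the scatter: nitro in place of methyl gives a 2.1-fold lower number from compound 2 to compound 3 (0.31 log units; beyond the scatter), and 4-nitrophenyl in place of 2-bromophenyl gives a 2.2-fold lower number from compound 1 to compound 3 (0.33 log units; beyond the scatter). Among these compounds, compound 1 and compound 2 had stayed within the scatter of each other, so this change is the first at this ring to exceed it, though both steps are modest. Nothing available explains the lower number at this carbon.

Open, going by these compounds, is whether the shift is specific to nitro or also appears with an amine, a nitrile or a carboxylic acid on the same carbon. Also open, on these data alone, is whether nitro gives the same step at another carbon of this ring.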